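Stereoisomers near the limit of a growth assay

The compounds below may be only part of what the source reports. "The series", "measured", "known", "first", "only" and "open" are said of these compounds alone.

Compound 3 `Cc1ccc(/C=C/[C@@]2(C)CC[C@@](C)(/C=C/C3=C[C@H](O)[C@](C)(O)C[C@@H]3O)O2)cc1` is one of three stereoisomers of a shared core tested in a functional assay on A549 cells (Homo sapiens) for inhibition, read by MTT assay, with a stated time of 72 h; a higher number here means a weaker inhibitor, a lower number a stronger inhibitor. Compound 3 gives only a limit there, > 50000 nM. Compound 1 `Cc1ccc(/C=C/[C@]2(C)CC[C@@](C)(/C=C/C3=C[C@H](O)[C@](C)(O)C[C@@H]3O)O2)cc1` likewise gives only a limit, > 50000 nM. For the measured compounds named here, compound 2 `Cc1ccc(/C=C/[C@@]2(C)CC[C@](C)(/C=C/C3=C[C@H](O)[C@](C)(O)C[C@@H]3O)O2)cc1` gives a number, 41300 nM, the only number among the three. The steps among them are small: an at least 1.2-fold lower number from compound 1 to compound 2 (0.08 log units; that floor lies within the scatter), an at least 1.2-fold higher number from compound 2 to compound 3 (0.08 log units; that floor lies within the scatter), and a step that the two limits leave unreadable from compound 1 to compound 3; because the limit of > 50000 nM in this assay, at which 2 of the 3 values shown sit, caps what these steps can show, none reads as beyond the scatter. Compound 4 `Cc1ccc(/C=C/[C@]2(C)CC[C@](C)(/C=C/C3=C[C@H](O)[C@](C)(O)C[C@@H]3O)O2)cc1` is the fourth stereoisomer; (the two compounds have the same atoms and bonds and differ only in configuration as drawn: 2 of 7 stereo elements differ; a stereocentre at a saturated ring carbon is drawn R in compound 3 and S in compound 4; a stereocentre at a saturated ring carbon is drawn S in compound 3 and R in compound 4). Going by the values given here, the nearest precedent is a two-centre change, an at least 1.2-fold lower number from compound 1 to compound 2 (0.08 log units; that floor lies within the scatter), which stayed within the scatter. For compound 4 the step is therefore expected to be a number no higher from compound 3 to compound 4 (the limit leaves the size open), nothing beyond the scatter. Compound 4 is estimated at 50000 nM, between 30000 nM and 100000 nM, with a limit rather than a number the likelier report.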

Compound 4, half-maximal inhibitory concentration: > 50000 nM
Compound 4 gave a limit, no number; the forecaster's own chance of this, stated with the estimate: 60%; the middle value lies on the limit itself.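

With compound 4, all four arrangements of the two stereocentres at saturated ring carbons stand in this assay, and still no change of configuration there gives a step that reads as beyond the scatter: an at least 1.2-fold higher number from compound 2 to compound 4 (0.08 log units; that floor lies within the scatter). The other two steps to compound 4 cannot be read, because both ends of each are limits: the limit of > 50000 nM in this assay, at which 3 of the 4 values shown sit. For the compounds shown here, compound 2 therefore remains the only stereoisomer with a number, and nothing shows that number to stand apart from the other three.

As far as these compounds go, whether compound 1, compound 3 and compound 4 differ among themselves stays open. Also open, from the compounds shown here alone, is whether an amine or a carboxylic acid added to the shared core would bring any of the four stereoisomers to a number clear of the limit.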